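The compounds below may be only part of what the source reports. "The series", "measured", "known", "first", "only" and "open" are said of these compounds alone.

Measured so far in a functional assay on the whole organism (strain albino) for inhibition, with Rattus norvegicus as the target, read by paw edema, with stated times of 30 min and 1 h, at a dose of 5 mg/kg by the oral route; on this read-out higher numbers stand for more inhibition at the one dose given (going by the name of the read-out) and lower numbers for less inhibition:

compound 1, `CCOC(=O)Cc1nc(N)n(C(=O)c2ccc(OC)cc2)n1`, gives 32.8%
compound 2, `CCOC(=O)Cc1nc(N)n(C(=O)c2ccc([N+](=O)[O-])cc2)n1`, gives 36.1%
compound 3, `CCOC(=O)Cc1n[nH]c(NC(=O)c2ccc(OC)cc2)n1`, gives 30.2%

Compound 1 and compound 3 are built from the same atoms joined differently; the difference between the two cores is not broken down here. Their values in this assay lie within the scatter of each other, so nothing is made of the gap.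

From compound 1 to compound 2 the change is nitro in place of methoxy on an aromatic carbon, and the step it made is a number 3.3 percentage points higher from compound 1 to compound 2 (within the scatter).

Compound 4, `CCOC(=O)Cc1n[nH]c(NC(=O)c2ccc([N+](=O)[O-])cc2)n1`, is not yet measured. It arises from compound 3 by nitro in place of methoxy on an aromatic carbon, the same change that carries compound 1 to compound 2, at a place described in identical words.

Going by the values given here, for compound 4 in this assay, a step of about a number 3.3 percentage points higher from compound 3 to compound 4 (within the scatter) is expected, resting on the one earlier instance of this change, which gave a number 3.3 percentage points higher from compound 1 to compound 2 (within the scatter) from compound 1 to compound 2. Among the compounds with values here, the single precedent sits within the scatter, so little more than a flat carry-over of compound 3 can be claimed.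

Compound 4 is therefore estimated at 33.5% in this assay, most likely between 24% and 43%.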

Compound 4, a percentage reported as inhibition, in the whole organism at one dose (the size of the read-out at that dose, not a potency): 32.6%
For compound 4 the middle estimate is 0.9 percentage points above the measured one; the range from low to high includes it.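

In this assay the swap of methoxy for nitro on an aromatic carbon can now be read on two cores, and the new step is a number 2.4 percentage points higher from compound 3 to compound 4 (within the scatter). Set beside the earlier step, the two agree: the same change on two cores in this assay, a number 3.3 percentage points higher (within the scatter) from compound 1 to compound 2 and a number 2.4 percentage points higher (within the scatter) from compound 3 to compound 4, 0.9 percentage points apart, within the scatter of two such steps. This shows that the change carries from one core to the other without a readable difference at this one dose, but with both steps inside the scatter, it does not show that the change alters inhibition on either core, so what carries over is the lack of a clear step, not a gain.

The compounds shown span only methoxy and nitro on the aromatic ring, so it remains open whether another group there, such as an amine or a carboxylic acid, would give a step beyond the scatter on either core. Also open, from the compounds shown here alone, is whether a carboxylic acid or a longer chain in place of the ethyl ester would separate the two cores.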